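Compound 3 to compound 4: one ring exchanged

A few compounds are considered here, and "the series" means these few. Any claim that something is new, unique, unknown or untested is made for them only; others in the source may bear on it.

Within the data shown here, in a functional assay on SMMC-7721 cells (Homo sapiens) for inhibition, read by MTT assay, with a stated time of 48 h (a higher number here means a weaker inhibitor, a lower number a stronger inhibitor), compound 3 `COc1ccc(-c2ccc(OC(F)(F)F)c(NC(=O)Nc3nccs3)c2)cn1` gives 44100 nM, the highest of the three numbers measured so far, which makes it the weakest inhibitor of the set. Compound 1 `O=C(Nc1ccccn1)Nc1cc(-c2cncnc2)ccc1OC(F)(F)F` gives 21600 nM and compound 2 `O=C(Nc1ccncc1)Nc1cc(-c2cncnc2)ccc1OC(F)(F)F` gives 3990 nM, and both carry a pyrimidin-5-yl group. Compound 4 `O=C(Nc1nccs1)Nc1cc(-c2cncnc2)ccc1OC(F)(F)F` has not been measured yet. It differs from compound 3 in one place, with pyrimidin-5-yl in place of 6-methoxypyridin-3-yl on an aromatic carbon.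

Among the measured compounds shown here, the one measured step, a 5.4-fold lower number from compound 1 to compound 2 (0.73 log units; beyond the scatter), exchanges pyridin-2-yl for pyridin-4-yl on an amide-type nitrogen. That is a different change, so it does not measure this exchange directly. For the measured compounds named here, it shows only that a single exchange can shift the number well beyond the scatter. Compound 1, at 21600 nM, has pyrimidin-5-yl and stands lower than compound 3, though the two also differ elsewhere. A modest fall in this assay is therefore expected, on thin evidence. The expected step is a 3.2-fold lower number from compound 3 to compound 4 (0.50 log units; beyond the scatter). For compound 4 the estimated value is 14000 nM, with an expected range from 4000 nM to 45000 nM.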

Compound 4, half-maximal inhibitory concentration: 9350 nM
Compound 4: the middle estimate sits 1.5-fold (0.18 log units) above what was measured, within the range that was stated.
By their numbers in this assay, from the lowest: compound 2; then compound 4; then compound 1; then compound 3.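

In this assay, among these compounds, the step of a 4.7-fold lower number from compound 3 to compound 4 (0.67 log units; beyond the scatter) is the first direct reading of the place para to the trifluoromethoxy group: with the (1,3-thiazol-2-yl)carbamoyl amino group held constant, pyrimidin-5-yl in place of 6-methoxypyridin-3-yl gives a stronger inhibitor, beyond the scatter. The new compound also extends the series at the amide-type nitrogen, where the shared pyrimidin-5-yl stays fixed: the step shows a 2.3-fold lower number from compound 1 to compound 4 (0.36 log units; beyond the scatter) and the reverse comparison shows a 2.3-fold higher number from compound 2 to compound 4 (0.37 log units; beyond the scatter) so 1,3-thiazol-2-yl falls between pyridin-2-yl and pyridin-4-yl in this assay. Both places on the molecule therefore move the number, each by a modest step.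

This single exchange changes the ring and removes the methoxy group together, so the compounds shown cannot say which part of the exchange matters, and a plain pyridin-3-yl, or a ring carrying an amine or a carboxylic acid at this place, would help to separate the two. No measurement is available here that explains why the number moves at either place.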